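The source may hold more compounds than are shown below. What is called first, only, known or untested is meant among the compounds shown, and "the series" means these compounds.

Compound 1, with the structure `CCOC(=O)c1ccc(NC(=O)N2CC2C#N)cc1`, is a urea built on a small strained ring that carries a nitrile, joined to a benzene ring bearing an ethoxycarbonyl group. Among the measured compounds shown here, in a functional assay on OVCAR-3 cells (Homo sapiens) for inhibition (a lower number here means a stronger inhibitor, a higher number a weaker inhibitor), compound 1 gives 7700 nM, and this is the only actual number among the values shown. Compound 2, with the structure `N#CC1CN1C(N)=O`, keeps the strained ring and the urea but has no aromatic part at all; in this assay compound 2 reaches only a limit of the method, > 90000 nM. That is what the limit of > 90000 nM in this assay, at which 1 of the 2 values shown sits, records, so compound 1 cannot yet be ranked against a second number.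

Compound 3, with the structure `N#CC1CN1C(=O)Nc1ccc(S(N)(=O)=O)cc1`, differs from compound 1 by one exchange: sulfamoyl in place of ethoxycarbonyl on an aromatic carbon. For the measured compounds named here, no measured pair shows what such an exchange does here. The change from compound 1 to compound 3 is expected to be small, a 1.3-fold higher number from compound 1 to compound 3 (0.11 log units; within the scatter), within the usual scatter or slightly towards weaker inhibition. Compound 3 is therefore estimated at 10000 nM, with a likely range from 3000 nM to 40000 nM.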

Compound 3, half-maximal inhibitory concentration: 188000 nM
For compound 3 the middle estimate is 19-fold (1.27 log units) below the measured one; the whole stated range lies below it.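

This exchange gives the first measured view of this aromatic carbon, and it shows that the group placed there matters greatly: in this assay, sulfamoyl in place of ethoxycarbonyl gives a 24-fold higher number from compound 1 to compound 3 (1.39 log units; beyond the scatter). Compound 3 keeps the aromatic ring and the rest of the core of compound 1, so in this pair the ring alone does not preserve inhibition, and the outcome depends on what it carries at this carbon. Nothing measured here accounts for the size of this step.

A single exchange cannot show which feature of ethoxycarbonyl matters, or whether any other group at this carbon would give a lower number. As far as these compounds go, a carboxylic acid, an amine or a longer ester chain at the same carbon would each test this further, and their effects remain open.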